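This account rests on a few compounds, and the source may have more. Where it says the series, first, only, none or still open, it means among the compounds named here.

Working notes on the series. Compound 1 `O=C(O)c1ccccc1-c1ccc(CCc2ncc(Cc3ccccc3F)[nH]2)cc1` carries a 2-fluorobenzyl on an aromatic carbon of the shared core, while compound 2 `O=C(O)c1ccccc1-c1ccc(CCc2ncc(-c3ccccc3)[nH]2)cc1` carries phenyl at the same place. Among the measured compounds shown here, in an in vitro functional assay on cells for agonist activity at Bombesin receptor subtype-3 (Mus musculus), read by luminescence and calcium flux (on this read-out lower numbers stand for an effect already at smaller amounts and higher numbers for an effect only at larger amounts of compound), compound 1 gives 9.5 nM; compound 2 gives 872 nM, the highest of the two numbers so far, with compound 1 as its only neighbour. For the measured compounds named here, the single measured step, a 92-fold higher number from compound 1 to compound 2 (1.96 log units; beyond the scatter), is large.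

Compound 3 `O=C(O)c1ccccc1-c1ccc(CCc2ncc(Cc3ccccc3)[nH]2)cc1` is not yet measured; it differs from compound 2 by benzyl in place of phenyl on an aromatic carbon. Going by the values given here, the one step that bears on this change is a 92-fold higher number from compound 1 to compound 2 (1.96 log units; beyond the scatter), which runs the opposite way, from a fluorinated benzyl to phenyl. Since benzyl lacks the fluorine present in compound 1, a return toward the number of compound 1 is expected, though possibly not the whole way. Compound 3 is therefore estimated at 25 nM, within 6 nM to 110 nM, which means an expected step of a 35-fold lower number from compound 2 to compound 3 (1.54 log units; beyond the scatter).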

Compound 3, half-maximal effective concentration: 11 nM
Compound 3: the middle estimate sits 2.3-fold (0.36 log units) above what was measured, and the stated range covers the measured number.
By their numbers in this assay, from the lowest: compounds 1 and 3 (each within the scatter of the next); then compound 2.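

In this assay, benzyl in place of phenyl on this aromatic carbon gives a 79-fold lower number from compound 2 to compound 3 (1.90 log units; beyond the scatter) and so shows that the large step seen earlier does not depend on the fluorine. Hydrogen in place of fluoro on the benzyl ring gives a 1.2-fold higher number from compound 1 to compound 3 (0.06 log units; within the scatter) and leaves the two numbers within the scatter, so the 2-fluoro group makes no readable difference in this assay. At this position the readable contrast in the compounds shown is therefore between benzyl, with or without the fluorine, and phenyl.

Going by these compounds, it remains open whether a longer chain such as phenethyl, or an amine joining the ring to the core in place of the benzyl carbon, would keep the number of compound 3 in this range. Nothing measured here gives a reason for the gap between benzyl and phenyl.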